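Shifting the chlorine on a urea-linked phenyl ring

A few compounds are considered here, and "the series" means these few. Any claim that something is new, unique, unknown or untested is made for them only; others in the source may bear on it.

Compound 1 `CN(C)CCNc1nc(-c2ccc(NC(=O)Nc3ccc(Cl)cc3)cc2)nc2c(Cl)c(Cl)sc12` gives 300 nM in a functional assay on NCI-H460 cells (Homo sapiens) for cytotoxicity, read by MTT assay, with a stated time of 72 h; on this read-out higher numbers stand for weaker inhibition and lower numbers for stronger inhibition. Compound 2 `CN(C)CCNc1nc(-c2ccc(NC(=O)Nc3ccccc3Cl)cc2)nc2c(Cl)c(Cl)sc12` differs from it by 2-chlorophenyl in place of 4-chlorophenyl on an amide-type nitrogen and gives 440 nM; the step of a 1.5-fold higher number from compound 1 to compound 2 (0.17 log units; within the scatter). Compound 3 `CCN(CC)CCCNc1nc(-c2ccc(NC(=O)Nc3ccc(Cl)cc3)cc2)nc2ccsc12` stands on a different core, and the difference between the two cores is not broken down here; in this assay compound 3 gives 81 nM, the lowest number of the three. Compound 4 `CCN(CC)CCCNc1nc(-c2ccc(NC(=O)Nc3ccccc3Cl)cc2)nc2ccsc12` is not yet measured and differs from compound 3 by 2-chlorophenyl in place of 4-chlorophenyl on an amide-type nitrogen, the same change at the same place as between compound 1 and compound 2. Because the earlier step of a 1.5-fold higher number from compound 1 to compound 2 (0.17 log units; within the scatter) stayed within the scatter, the step from compound 3 to compound 4 is expected to be similar, a 1.5-fold higher number from compound 3 to compound 4 (0.17 log units; within the scatter). Compound 4 is therefore estimated at 120 nM, between 60 nM and 250 nM.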

Compound 4, half-maximal inhibitory concentration: 200 nM
For compound 4 the middle estimate is 1.7-fold (0.22 log units) below the measured one, within the range that was stated.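

In this assay, 2-chlorophenyl in place of 4-chlorophenyl on the amide-type nitrogen gives a 2.5-fold higher number from compound 3 to compound 4 (0.39 log units; beyond the scatter), a step beyond the scatter, whereas the earlier step was not, yet the two steps cannot be told apart: the same change on two cores in this assay, a 1.5-fold higher number (0.17 log units; within the scatter) from compound 1 to compound 2 and a 2.5-fold higher number (0.39 log units; beyond the scatter) from compound 3 to compound 4, 1.7-fold (0.23 log units) apart, within the scatter of two such steps The change therefore carries from the core of compound 1 to the core of compound 3 without a measurable difference in its size. This rests on one pair per core, and it does not show that the step would hold on any further core.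

The compounds shown leave open whether a fluorine or a methoxy group in place of the chlorine would behave alike. They also leave open how the step would fare with a carboxylic acid on the side chain in place of the amine.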